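A few compounds are considered here, and "the series" means these few. Any claim that something is new, unique, unknown or untested is made for them only; others in the source may bear on it.

Measured compounds:
- compound 1, `COc1cccc(/C=C/C(=O)NNC(=O)c2ccc3c(c2)OCCO3)c1`: 398000 nM
- compound 2, `O=C(/C=C/c1ccc(F)cc1)NNC(=O)c1ccc2c(c1)OCCO2`: 319000 nM
- compound 3, `O=C(/C=C/c1ccccc1)NNC(=O)c1ccc2c(c1)OCCO2`: 312000 nM

All three numbers come from an ADME assay on cells (Macrophage) for cytotoxicity, read by MTT assay, with a stated time of 24 h; on this read-out lower numbers stand for higher toxicity in this test and higher numbers for lower toxicity in this test. Compound 2 gives the second highest number of the three; the step of a 1.0-fold lower number from compound 2 to compound 3 (0.01 log units; within the scatter) is negligible, and the step of a 1.2-fold lower number from compound 1 to compound 2 (0.10 log units; within the scatter) is the widest gap compound 2 has here, still within the scatter. Compound 4, `O=C(/C=C/c1ccccc1[N+](=O)[O-])NNC(=O)c1ccc2c(c1)OCCO2`, has not been measured. It differs from compound 2 as follows: 2-nitrophenyl in place of 4-fluorophenyl on a double-bonded chain carbon bound to a double-bonded chain carbon. For the measured compounds named here, the steps that bear on an exchange of the ring on the double-bonded chain carbon are a 1.2-fold lower number from compound 1 to compound 2 (0.10 log units; within the scatter) and a 1.0-fold lower number from compound 2 to compound 3 (0.01 log units; within the scatter), both within the scatter, so no step beyond the scatter is expected for 2-nitrophenyl either. For compound 4 the expected step is a 1.0-fold higher number from compound 2 to compound 4 (0.00 log units; within the scatter). Compound 4 is estimated at 320000 nM, within 160000 nM to 640000 nM.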

Compound 4, half-maximal cytotoxic concentration: 257000 nM
Estimate against measurement, compound 4: 1.2-fold (0.10 log units) above, within the range that was stated.
By their numbers in this assay, from the lowest: compounds 4, 3, 2 and 1 (each within the scatter of the next).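

In this assay the 2-nitrophenyl ring gives a 1.2-fold lower number from compound 2 to compound 4 (0.09 log units; within the scatter) and a 1.2-fold lower number from compound 3 to compound 4 (0.08 log units; within the scatter) and a 1.5-fold lower number from compound 1 to compound 4 (0.19 log units; within the scatter), so all three steps remain within the scatter. The earlier compounds shown here carried only fluoro, methoxy or hydrogen on this ring; nitro, a larger group with hydrogen-bond acceptors, now also gives no step beyond the scatter at this place. No measured evidence here accounts for this result. Open, on these data alone, is whether an amine or a carboxylic acid on this ring, or a longer chain in place of the ring, would give a step beyond the scatter.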